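Indolyl exchange from compound 3 to compound 4

A few compounds are considered here, and "the series" means these few. Any claim that something is new, unique, unknown or untested is made for them only; others in the source may bear on it.

Measured in a functional assay on HCT-116 cells (Homo sapiens) for inhibition, read by CCK-8 assay, with a stated time of 48 h; on this read-out higher numbers stand for weaker inhibition and lower numbers for stronger inhibition:
- compound 1 `COc1cc(-c2ccnc3cc(-c4cn(CO)c5ccccc45)nn23)cc(OC)c1OC`: 128 nM
- compound 2 `COc1cc(-c2ccnc3cc(-c4ccc(C)c(C)c4)nn23)cc(OC)c1OC`: 261 nM
- compound 3 `COc1cc(-c2ccnc3cc(-c4ccc5cc[nH]c5c4)nn23)cc(OC)c1OC`: 187 nM

Compound 3, at 187 nM, lies within the scatter of both other compounds. Its nearest neighbour by value is compound 2, and compound 1 is the furthest from it, yet that gap also stays within the scatter.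

The next compound is compound 4 `COc1cc(-c2ccnc3cc(-c4cn(C)c5ccccc45)nn23)cc(OC)c1OC`. The structural change from compound 3 is 1-methyl-1H-indol-3-yl in place of 1H-indol-6-yl on an aromatic carbon. The group sits on an aromatic carbon of a five-membered aromatic ring with 2 nitrogen, and the hydrogen-bond donor of the leaving group is absent from the entering one.

Within the data shown here, only one measured step bears on this change: a 1.4-fold lower number from compound 2 to compound 3 (0.14 log units; within the scatter). That step brought in the 1H-indol-6-yl group that now leaves, and it stayed within the scatter. Among the measured compounds shown here, no measured step brings in 1-methyl-1H-indol-3-yl, so the direction rests on thin evidence. The expectation leans slightly towards the value of compound 1, 128 nM, and no move beyond the scatter is foreseen in this assay.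

The expected change is a 1.2-fold lower number from compound 3 to compound 4 (0.10 log units; within the scatter).

For compound 4 the estimated value is 150 nM, with an expected range from 65 nM to 350 nM.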

Compound 4, half-maximal inhibitory concentration: 762 nM
Beside the measured number, compound 4's estimate is 5.1-fold (0.71 log units) below it; measured number outside the range, above it.
By their numbers in this assay, from the lowest: compounds 1, 3 and 2 (each within the scatter of the next, the first and the last beyond it); then compound 4.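

In this assay this position proves sensitive to the group it carries: 1-methyl-1H-indol-3-yl in place of 1H-indol-6-yl gives a 4.1-fold higher number from compound 3 to compound 4 (0.61 log units; beyond the scatter) on the aromatic carbon of the five-membered aromatic ring with 2 nitrogen, whereas a 1.4-fold lower number from compound 2 to compound 3 (0.14 log units; within the scatter) had shown no separation between two other groups there. The same entering group also gives a 2.9-fold higher number from compound 2 to compound 4 (0.47 log units; beyond the scatter) against 3,4-dimethylphenyl, so compound 4 stands apart from both of these compounds. The largest step is a 6.0-fold higher number from compound 1 to compound 4 (0.77 log units; beyond the scatter) with hydrogen in place of hydroxy on a saturated chain carbon bound to an aromatic nitrogen, which shows that the substituent on that chain matters in this series as well as the choice of aromatic group.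

The step from compound 3 to compound 4 changes the point of attachment and the nitrogen substituent together, so 1H-indol-3-yl and 1-methyl-1H-indol-6-yl would be needed to separate the two. The compounds also leave open how a methoxy, an amine or a carboxylic acid on that saturated chain carbon would compare with hydroxy. No measurement at hand offers an explanation for any of these steps.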